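This account rests on a few compounds, and the source may have more. Where it says the series, first, only, none or still open, it means among the compounds named here.

Measured in a functional assay on MCF7 cells (Homo sapiens) for antiproliferative activity, read by MTT assay, with a stated time of 48 h; a higher number here means a weaker inhibitor, a lower number a stronger inhibitor:
Compound 1, `COc1ccc2c(/C=C/C(=O)c3cc(OC)c(OC)c(SC)c3)c[nH]c2c1`, gives 101 nM.
Compound 2, `COc1ccc2c(/C=C/C(=O)c3cc(OC)c(OC)c(SC)c3)cn(C)c2c1`, gives 166 nM.
Compound 3, `COc1cc(C(=O)/C=C/c2cn(C)c3ccccc23)cc(N)c1OC`, gives 631 nM.

Compounds 1 and 2 share one core, while compound 3 is built on another; the difference between the two cores is not broken down here. Within the first pair a single change has been measured: hydrogen in place of methyl on an aromatic nitrogen, (hydrogen in place of methyl on an aromatic nitrogen). It made a 1.6-fold lower number from compound 2 to compound 1 (0.22 log units; within the scatter), a step that stays within the usual scatter of repeated measurements, so the two values cannot be put in any order. Compound 3 stands apart with a number higher than either of them, and its gap to compound 2 as well as to compound 1 lies beyond the scatter.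

Compound 4, `COc1cc(C(=O)/C=C/c2c[nH]c3ccccc23)cc(N)c1OC`, has not yet been measured. It differs from compound 3 by the same kind of change, hydrogen in place of methyl on an aromatic nitrogen, (hydrogen in place of methyl on an aromatic nitrogen). The surroundings of the place read alike in both cases, so this is the same change carried onto a different core. Among the compounds with values here, only one earlier example of it exists, and that example sits on another core, so the expectation is a loose one. In this assay the change is expected to give a 1.6-fold lower number from compound 3 to compound 4 (0.20 log units; within the scatter), resting on the measured step of a 1.6-fold lower number from compound 2 to compound 1 (0.22 log units; within the scatter). For compound 4 a value of 400 nM is estimated, expected to fall between 200 nM and 800 nM.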

Compound 4, half-maximal inhibitory concentration: 595 nM
The estimate for compound 4 lay 1.5-fold (0.17 log units) below the measured number, and the stated range covers the measured number.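

In this assay, putting hydrogen in place of methyl on the aromatic nitrogen gives a 1.1-fold lower number from compound 3 to compound 4 (0.03 log units; within the scatter), so compound 3 and compound 4 cannot be put in any order. Set beside the earlier example of the same change, this step does not differ from it by more than the scatter expected for two such steps: the same change on two cores in this assay, a 1.6-fold lower number (0.22 log units; within the scatter) from compound 2 to compound 1 and a 1.1-fold lower number (0.03 log units; within the scatter) from compound 3 to compound 4, 1.5-fold (0.19 log units) apart, within the scatter of two such steps. In this small series, the change therefore reads alike on both cores, with no measurable effect on either, but two pairs cannot show that it would behave this way on other cores, and steps this small cannot reveal a real but slight effect or a slight difference between the two cores.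

On these data alone, what would happen with a longer chain, such as an ethyl or a benzyl group, on the same aromatic nitrogen remains open, since only hydrogen and methyl appear there. The two cores also differ in more than one place, so the compounds shown cannot say which of those differences matters for the numbers in this assay.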